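The source may hold more compounds than are shown below. What is called first, only, known or untested is meant among the compounds shown, and "the series" means these compounds.

In an assay on isolated protein for inhibition of histone deacetylase 4 (Homo sapiens), read by fluorescence (a higher number here means a weaker inhibitor, a lower number a stronger inhibitor), three compounds have been measured:

Compound 1 `O=C(NO)c1ccc(/C=C/c2ccc(O)cc2)o1` gives 57100 nM.
Compound 2 `O=C(/C=C/c1ccc(/C=C/C(=O)c2cccc(Cl)c2)o1)NO` gives 12900 nM.
Compound 3 `O=C(/C=C/c1ccc(/C=C/C(=O)c2ccccc2)o1)NO` gives 22800 nM.

Among these three numbers compound 3 stands second highest: compound 2 lies close to it, and the step of a 1.8-fold higher number from compound 2 to compound 3 (0.25 log units; within the scatter) is within the scatter, while compound 1 gives a number beyond the scatter higher than compound 3. The unmeasured compound 4 `O=C(/C=C/c1ccc(/C=C/C(=O)c2ccc(Cl)cc2)o1)NO` differs from compound 3 in one place: chloro in place of hydrogen on an aromatic carbon. Among the measured compounds shown here, the only measured step that bears on this change is the removal of a chloro group elsewhere on the same ring, a 1.8-fold higher number from compound 2 to compound 3 (0.25 log units; within the scatter), which was too small to count as a real difference. A chloro at the new place is therefore expected to move the number in this assay only a little, if at all, with the direction leaning toward a slightly lower number in line with the step from compound 2 to compound 3. For compound 4 the expected result is 15000 nM, in a range from 6000 nM to 40000 nM, which means an estimated step of a 1.5-fold lower number from compound 3 to compound 4 (0.18 log units; within the scatter).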

Compound 4, half-maximal inhibitory concentration: 6030 nM
Compound 4: middle estimate off by 2.5-fold (0.40 log units), on the high side; the measured number falls inside the stated range.
By their numbers in this assay, from the lowest: compound 4; then compounds 2 and 3 (each within the scatter of the next); then compound 1.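

In this assay, chloro on the phenyl ring, para to a large group, gives a 3.8-fold lower number from compound 3 to compound 4 (0.58 log units; beyond the scatter) and so, unlike the chloro step between compound 2 and compound 3, a change beyond the scatter, though a modest one. Moving the chlorine gives a 2.1-fold lower number from compound 2 to compound 4 (0.33 log units; beyond the scatter) as 3-chlorophenyl becomes 4-chlorophenyl, so among these compounds the place of the chloro on the ring affects the number, and not only its presence. No measurement at hand explains why this place gives the stronger inhibitor.

As far as these compounds go, this is a single substituent at this place, so it remains open whether the result is particular to chloro. A fluoro, a methoxy or an amine at the same carbon could give a higher number, a lower one or much the same.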